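The source may report more compounds than this note shows. Statements on the series, on what has been measured and on what is new or still open speak of the compounds shown alone.

Compound 2, with the structure `CCCCCCCCCCCC(=O)O[C@H]1[C@H](O)[C@H](n2ccc(N)nc2=O)O[C@@H]1CO`, is one of two measured esters of the same core. In a functional assay on HeLa cells (Homo sapiens) for cytotoxicity, read by cell counting, with a stated time of 48 h (on this read-out higher numbers stand for an effect only at larger amounts of compound and lower numbers for an effect already at smaller amounts), compound 2 gives 0.08 ug/mL. Compound 1, the structure `CCCCCCCCCC(=O)O[C@H]1[C@H](O)[C@H](n2ccc(N)nc2=O)O[C@@H]1CO`, differs from it only in the length of the acyl chain; in this assay compound 1 gives 0.09 ug/mL. The two numbers are not separable from each other: the step of a 1.1-fold lower number from compound 1 to compound 2 (0.05 log units; within the scatter) is within the scatter, so compound 2 stands no further from compound 1 than repeated measurements would.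

Compound 3, the structure `CCCCCCCC(=O)O[C@H]1[C@H](O)[C@H](n2ccc(N)nc2=O)O[C@@H]1CO`, is not yet measured in this assay. Its difference from compound 2 is hydrogen in place of butyl on a saturated chain carbon, seven bonds along the chain from a carbonyl carbon, that is, a shortening of the same acyl chain. Within the data shown here, only the step from compound 1 to compound 2 bears on this change, and it was within the scatter, though it ran in the other direction and over a shorter piece of chain. The shortening in compound 3 is larger than that, so the expected step of a 1.9-fold higher number from compound 2 to compound 3 (0.27 log units; within the scatter) is a modest rise in the number, not clearly beyond the scatter. Compound 3 is therefore expected to give about 0.15 ug/mL in this assay, estimated to lie between 0.06 ug/mL and 0.45 ug/mL.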

Compound 3, concentration for half-maximal effect: 0.1 ug/mL
Beside the measured number, compound 3's estimate is 1.5-fold (0.18 log units) above it, and the stated range covers the measured number.
By their numbers in this assay, from the lowest: compounds 2, 1 and 3 (each within the scatter of the next).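

In this assay, hydrogen in place of butyl on a saturated chain carbon, seven bonds along the chain from a carbonyl carbon, gives a 1.3-fold higher number from compound 2 to compound 3 (0.10 log units; within the scatter), and hydrogen in place of ethyl at that same place gives a 1.1-fold higher number from compound 1 to compound 3 (0.05 log units; within the scatter); both steps are within the scatter. The earlier compounds offered only one step, ethyl in place of hydrogen nine bonds along the chain, whereas compound 1, compound 2 and compound 3 now form a set of three esters of the shared core that cannot be told apart in this read-out, so taking butyl off this carbon leaves the number within the scatter of the longest chain shown. Nothing at hand bears on why the numbers of these three esters cannot be separated.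

The compounds shown leave open whether this holds for a shorter acyl group such as acetyl, for a longer chain such as hexadecanoyl, or for a chain ending in an amine or a carboxylic acid. They also leave open what an amide in place of the ester would give on the same core.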